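The source may report more compounds than this note shows. Statements on the series, on what has been measured and on what is new or still open speak of the compounds shown alone.

Measured compounds:
compound 1, `CC(=O)Nc1cccc(S(=O)(=O)Oc2ccccc2C(C)C)c1`: 21000 nM in a functional assay on MCF7 cells (Homo sapiens) for antiproliferative activity, read by sulforhodamine B assay, with a stated time of 48 h; on this read-out lower numbers stand for stronger inhibition and higher numbers for weaker inhibition
compound 2, `CCCCCC(=O)Nc1ccc(S(=O)(=O)Oc2ccccc2C(C)C)cc1`: 5300 nM in this assay
compound 3, `CCCCCC(=O)Nc1ccc(S(=O)(=O)Oc2ccccc2I)cc1`: 10000 nM in this assay

Compound 2 gives the lowest number of the three in this assay. Compound 3 sits nearest, and the step of a 1.9-fold higher number from compound 2 to compound 3 (0.28 log units; within the scatter) lies within the scatter, so the two cannot be ordered. Compound 1 lies furthest off, its value standing beyond the scatter from that of compound 2; compound 1 and compound 2 differ in more than one place, so this gap is not assigned to a single change.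

Compound 4, `CCCNC(=O)Nc1ccc(S(=O)(=O)Oc2ccccc2C(C)C)cc1`, is not yet measured. It differs from compound 2 by propylamino in place of pentyl on a carbonyl carbon. Within the data shown here, none of the measured steps touches the carbonyl carbon: the only single-place step, from compound 2 to compound 3, changes the aromatic substituent and is within the scatter, so it gives no guide here. Without a comparable step, no change beyond the scatter is expected; a modest move toward a higher number is the working guess, the step from compound 2 to compound 4 estimated as a 1.4-fold higher number from compound 2 to compound 4 (0.15 log units; within the scatter). Compound 4 is expected to give about 7500 nM in this assay, within 3000 nM to 20000 nM.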

Compound 4, half-maximal inhibitory concentration: 2700 nM
Compound 4: middle estimate off by 2.8-fold (0.44 log units), on the high side; measured number outside the range, below it.
By their numbers in this assay, from the lowest: compounds 4, 2 and 3 (each within the scatter of the next, the first and the last beyond it); then compound 1.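

In this assay, among these compounds, the first change at the carbonyl carbon, propylamino in place of pentyl, gives a 2.0-fold lower number from compound 2 to compound 4 (0.29 log units; within the scatter) and so leaves compound 2 and compound 4 unordered. Within this pair, the number stays within the scatter when pentyl, with 0 hydrogen-bond donors, gives way to propylamino, with 1 hydrogen-bond donor, and the (pentylcarbonyl)amino group becomes (propylcarbamoyl)amino. No measurement offers an explanation for this result.

As far as these compounds go, whether a longer chain on the nitrogen, such as hexylamino, or a cyclic amine such as piperidine at the carbonyl carbon would move the number beyond the scatter remains open. From the compounds shown here alone, it also remains open whether iodo in place of isopropyl on an aromatic carbon would give a comparable step with propylamino in place.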